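Swapping a Fluorophenyl for a Phenol on a Sulfonamide

The compounds below may be only part of what the source reports. "The series", "measured", "known", "first", "only" and "open" are said of these compounds alone.

Compound 2 `O=S(=O)(Nc1ccc2oc(-c3ccccc3)nc2c1)c1ccccc1F` was examined in an assay on isolated protein for inhibition of malate dehydrogenase, mitochondrial (Sus scrofa), with stated times of 45 min and 30 min (a higher number here means a weaker inhibitor, a lower number a stronger inhibitor), and there compound 2 gives only > 63000 nM, which is a limit of the assay and not a number. Compound 1 `O=S(=O)(Nc1ccc(-c2nc3ccccc3o2)cc1)c1ccccc1Cl` likewise reaches only a limit in this assay, giving > 63000 nM. Compound 3 `O=[N+]([O-])c1cc(S(=O)(=O)Nc2ccc(-c3nc4ccccc4o3)cc2)ccc1Cl` in this assay also yields a limit, > 63000 nM. Every measured value therefore sits at the same point, as the limit of > 63000 nM in this assay, at which 3 of the 3 values shown sit, records, and compound 2 stands with the others at that limit without a number of its own. Within the data shown here, no step between two measured compounds can be drawn from such data.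

Compound 4 `O=S(=O)(Nc1ccc2oc(-c3ccccc3)nc2c1)c1ccc(O)cc1` differs from compound 2 by 4-hydroxyphenyl in place of 2-fluorophenyl on a sulfonyl sulfur. With nothing but limits to build on, one expects a step in this assay of none beyond the scatter, in either direction. Compound 4 is expected to give an estimate of 80000 nM, within 20000 nM to 300000 nM, and the expected step that the limit leaves unreadable from compound 2 to compound 4 is thus taken as essentially flat, with compound 4 most likely remaining at the limit.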

Compound 4, half-maximal inhibitory concentration: > 63000 nM
Compound 4 ended at the assay's limit; the forecaster's own chance of this, stated with the estimate: 80%; the middle value is on the limit's open side.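

Compound 2 and compound 4 both rest at a limit of this assay and not at a number, so no step can be read between them, and this holds for every compound shown: the limit of > 63000 nM in this assay, at which 4 of the 4 values shown sit.

The compounds shown leave open how 4-hydroxyphenyl and 2-fluorophenyl on a sulfonyl sulfur truly compare, and whether any change to these structures would yield a measurable value.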